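Phenyl in Place of Allyl on the Ring Carbon

This account rests on a few compounds, and the source may have more. Where it says the series, first, only, none or still open, it means among the compounds named here.

Compound 1 `C=CCC1C(=C)C(=O)N(c2ccccc2)N1c1ccccc1` is the reference point of the two measurements at hand. In a functional assay on NALM-6 cells (Homo sapiens) for inhibition, read by MTT assay, with a stated time of 48 h (a lower number here means a stronger inhibitor, a higher number a weaker inhibitor), compound 1 gives 740 nM, the lowest of the two numbers. Among the measured compounds shown here, compound 2 `C=C1CN(C)N(c2ccccc2)C1=O` gives 56000 nM in this assay, a gap beyond the scatter; compound 2 differs from compound 1 in more than one place, so the two values show only that compound 2 is the weaker inhibitor of the pair.

Compound 3 `C=C1C(=O)N(c2ccccc2)N(c2ccccc2)C1c1ccccc1` has not yet been measured. It differs from compound 1 in one place: phenyl in place of allyl on a saturated ring carbon. For the measured compounds named here, no step between two measured compounds isolates this change, so the size of the step cannot be read from the series; it is expected to be modest, with no direction clearly beyond the scatter. The change is expected to amount to a 1.2-fold lower number from compound 1 to compound 3 (0.09 log units; within the scatter). Compound 3 is therefore estimated to give about 600 nM in this assay, within a range from 200 nM to 2000 nM.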

Compound 3, half-maximal inhibitory concentration: 3820 nM
Estimate against measurement, compound 3: 6.4-fold (0.80 log units) below, and the stated range ends below it.
By their numbers in this assay, from the lowest: compound 1; then compound 3; then compound 2.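

In this assay, among the compounds shown here, phenyl in place of allyl on the saturated ring carbon gives a 5.2-fold higher number from compound 1 to compound 3 (0.71 log units; beyond the scatter), the first single change that can be read directly. This ring carbon is therefore sensitive to the group it carries, and of the two groups compared here, allyl gives the lower number. Nothing measured on these compounds accounts for the step.

For the compounds shown here, with only two groups compared at this carbon, the data cannot separate the effect of losing allyl from that of introducing phenyl. A saturated propyl chain, a benzyl group or an amine at the same ring carbon would help show which feature of the substituent tracks with the number in this assay.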